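Swapping Morpholine for Thiomorpholine on a Thiosemicarbazone

This account rests on a few compounds, and the source may have more. Where it says the series, first, only, none or still open, it means among the compounds named here.

Measured compounds and their growth inhibition:
- compound 1 `N/C(=N\NC(=S)N1CCOCC1)c1ccc(F)cn1`: 33.9%
- compound 2 `N/C(=N\NC(=S)N1CCOCC1)c1ccccn1`: 44.5%
- compound 3 `Cc1ccnc(/C(N)=N/NC(=S)N2CCCCC2)c1`: 29.4%

In a functional assay on MCF7 cells (Homo sapiens) for cytotoxicity, read by MTT assay, with a stated time of 72 h, tested at 3 uM (on this read-out higher numbers stand for more inhibition of growth at the one concentration tested and lower numbers for less inhibition of growth), compound 1 gives 33.9%, the second highest of the three numbers. Compound 3 gives 29.4%, which lies within the scatter of compound 1. Compound 2 is higher: a number 10.6 percentage points higher from compound 1 to compound 2 (beyond the scatter).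

Compound 4 `N/C(=N\NC(=S)N1CCSCC1)c1ccc(F)cn1` is not yet measured. It differs from compound 1 in one place: thiomorpholin-4-yl in place of morpholin-4-yl on a thiocarbonyl carbon. Within the data shown here, no measured step changes this part of the molecule, so nothing in the data speaks for a step in either direction beyond the scatter. Compound 4 is therefore expected to land near compound 1, with an estimated step of a number 0.1 percentage points higher from compound 1 to compound 4 (within the scatter). The estimate for compound 4 is 34%, expected between 20% and 50%.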

Compound 4, percent growth inhibition at one concentration: 35.4%
The estimate for compound 4 lay 1.4 percentage points below the measured number, and the stated range covers the measured number.
By their numbers in this assay, from the lowest: compounds 3, 1, 4 and 2 (each within the scatter of the next, the first and the last beyond it).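

In this assay, thiomorpholin-4-yl in place of morpholin-4-yl on the thiocarbonyl carbon gives a number 1.5 percentage points higher from compound 1 to compound 4 (within the scatter). Among these compounds, this is the first measured change at this position, and it shows that, on the fluoro-bearing core, the two rings cannot be told apart at the one concentration tested. Nothing available explains why they read alike. As far as these compounds go, whether the same swap behaves alike on the core of compound 2, which lacks the fluoro group, remains open. So does the outcome with a piperazin-1-yl ring or a dimethylamino group on the thiocarbonyl carbon.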